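The source may report more compounds than this note shows. Statements on the series, on what has been measured and on what is new or still open speak of the compounds shown alone.

Measured compounds:
- Compound 1, `CCN(CC)S(=O)(=O)c1ccc(S(=O)(=O)N2CCC[C@@H](C(=O)N3CCS(=O)(=O)CC3)C2)cc1`: 4430 nM
- Compound 2, `CCC(CC)S(=O)(=O)c1ccc(S(=O)(=O)N2CCC[C@@H](C(=O)N3CCC(F)(F)CC3)C2)cc1`: 40 nM
- Compound 3, `O=C([C@@H]1CCCN(S(=O)(=O)c2ccc(S(=O)(=O)N3CC[C@H](O)C3)cc2)C1)N1CCC(F)(F)CC1`: 580 nM

In a functional assay on BXPC-3 cells (Homo sapiens) for inhibition, read by MTT assay, with a stated time of 7 days (on this read-out higher numbers stand for weaker inhibition and lower numbers for stronger inhibition), compound 1 gives 4430 nM, the highest number of the three, so it is the weakest inhibitor shown. Compound 2 gives 40 nM and compound 3 gives 580 nM. Going by the values given here, the only single-point step among the measured compounds is a 15-fold higher number from compound 2 to compound 3 (1.16 log units; beyond the scatter), and it concerns the group on the sulfonyl sulfur, not the amide end of the shared core.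

Compound 4, `CCN(CC)S(=O)(=O)c1ccc(S(=O)(=O)N2CCC[C@@H](C(=O)N3CC[C@H](OC)C3)C2)cc1`, differs from compound 1 at the other end of the shared core: 3-methoxypyrrolidin-1-yl in place of 1,1-dioxothiomorpholin-4-yl on a carbonyl carbon

Among the compounds with values here, no measured step touches the group on the carbonyl carbon, so the measured data give no direct guide to the size or direction of this change. Compound 1 keeps the diethylamino group on the sulfonyl sulfur that is not present in compound 2 or compound 3, so their values cannot be carried over either. In the absence of a precedent, the expected step of a 2.2-fold lower number from compound 1 to compound 4 (0.35 log units; beyond the scatter) is modest, with wide uncertainty in both directions. Compound 4 is therefore estimated at 2000 nM, within a range of 400 nM to 10000 nM.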

Compound 4, half-maximal inhibitory concentration: 6750 nM
Compound 4: middle estimate off by 3.4-fold (0.53 log units), on the low side, and the stated range covers the measured number.
By their numbers in this assay, from the lowest: compound 2; then compound 3; then compounds 1 and 4 (each within the scatter of the next).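

In this assay, putting 3-methoxypyrrolidin-1-yl in place of 1,1-dioxothiomorpholin-4-yl on the carbonyl carbon gives a 1.5-fold higher number from compound 1 to compound 4 (0.18 log units; within the scatter) and so does not separate the two compounds. Going by these compounds alone, this is the first measured view of this position, and with the diethylamino group on the sulfonyl sulfur, a six-membered ring carrying the sulfone can give way to a five-membered ring with a methoxy group and a defined stereocentre without a change that can be read. The data offer no measured explanation for this result.

As far as these compounds go, it remains open whether this holds when pentan-3-yl sits on the sulfonyl sulfur, where the group on the carbonyl carbon could count for more or less. A simple piperidin-1-yl or morpholin-4-yl on the carbonyl carbon would also test how widely the finding applies.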